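Chloro to Cyano Swap on Two Related Cores

The compounds below may be only part of what the source reports. "The series", "measured", "known", "first", "only" and "open" are said of these compounds alone.

Of the compounds shown here, three have been tested in a functional assay on the whole organism for inhibition, with Rattus norvegicus as the target, at a dose of 30 mg/kg; on this read-out lower numbers stand for less inhibition and higher numbers for more inhibition at the one dose given (going by the name of the read-out). Compound 1 `Clc1ccccc1-c1nc2ncccc2o1` gives 38%. Compound 3 `N#Cc1ccccc1-c1nc2ncccc2o1` gives 62% in this assay. Compound 2 `Clc1ccc(-c2nc3cccnc3o2)cc1` gives 14% and stands lowest of the three, with both other compounds above it beyond the scatter. Compound 1 and compound 2 are built from the same atoms joined differently; the difference between the two cores is not broken down here.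

Going by the values given here, the one measured step between compounds that differ in a single place runs from compound 1 to compound 3, namely cyano in place of chloro on an aromatic carbon That step gives a number 24 percentage points higher from compound 1 to compound 3 (beyond the scatter).

Compound 4 `N#Cc1ccc(-c2nc3cccnc3o2)cc1` has not yet been measured. Among the compounds with values here, it differs from compound 2 by cyano in place of chloro on an aromatic carbon This is the same kind of change as the one from compound 1 to compound 3, but not the same: in compound 3 the cyano sits ortho to a group of 9 heavy atoms, in compound 4 para to a group of 9 heavy atoms. Resting on the step of a number 24 percentage points higher from compound 1 to compound 3 (beyond the scatter), a rise of roughly the same kind is expected, a number 20 percentage points higher from compound 2 to compound 4 (beyond the scatter), though tempered by the low start of compound 2 at 14% in this assay. Compound 4 is therefore estimated at 34% in this assay, expected to fall between 16% and 54%.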

Compound 4, a percentage reported as inhibition, in the whole organism at one dose (the size of the read-out at that dose, not a potency): 17%
Compound 4: middle estimate off by 17 percentage points, on the high side; the range from low to high includes it.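

In this assay, putting cyano in place of chloro on the core of compound 2 gives a number 3 percentage points higher from compound 2 to compound 4 (within the scatter), so on this core the swap leaves the two numbers indistinguishable. On the core of compound 1, the same kind of swap gave a clear rise, and the two results do not agree: the same change on two cores in this assay, a number 24 percentage points higher (beyond the scatter) from compound 1 to compound 3 and a number 3 percentage points higher (within the scatter) from compound 2 to compound 4, 21 percentage points apart, beyond the scatter of two such steps. This shows that the gain seen with one core cannot simply be assumed for another in this series, but it does not show what sets the two results apart, since the two pairs differ both in the core and in where the group sits on the ring, and two pairs alone cannot separate those factors.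

The compounds shown leave open what an amine or a carboxylic acid in place of the chloro would do in this assay on either core. They also leave open whether cyano in place of chloro on a further core would give a large step or a negligible one.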